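Hydroxy in place of anilino on a double-bonded nitrogen

The compounds below may be only part of what the source reports. "The series", "measured", "known", "first", "only" and "open" are said of these compounds alone.

Measured in an ADME assay on Vero cells (Chlorocebus sabaeus) for cytotoxicity, read by MTT assay, with a stated time of 72 h; on this read-out lower numbers stand for higher toxicity in this test and higher numbers for lower toxicity in this test:
- compound 1 `CCOC(=O)CN1CCN(c2c(F)cc3c(=O)c(C(=O)O)cn(C4CC4)c3c2OC)CC1C`: 1000 ug/mL
- compound 2 `COc1c(N2CCN(CCC(C)=O)C(C)C2)c(F)cc2c(=O)c(C(=O)O)cn(C3CC3)c12`: 9.84 ug/mL
- compound 3 `COc1c(N2CCN(C/C(C)=N/Nc3ccccc3)C(C)C2)c(F)cc2c(=O)c(C(=O)O)cn(C3CC3)c12`: 11.1 ug/mL

Compound 3, at 11.1 ug/mL, sits level with compound 2 within the scatter, the step being a 1.1-fold higher number from compound 2 to compound 3 (0.05 log units; within the scatter). Compound 1 stands far apart, with a 90-fold lower number from compound 1 to compound 3 (1.95 log units; beyond the scatter).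

The next structure is compound 4 `COc1c(N2CCN(C/C(C)=N/O)C(C)C2)c(F)cc2c(=O)c(C(=O)O)cn(C3CC3)c12`, with hydroxy in place of anilino on a double-bonded nitrogen. Among the measured compounds shown here, no measured step makes this exact exchange. The closest evidence is a 1.1-fold higher number from compound 2 to compound 3 (0.05 log units; within the scatter), where the end of the chain changed greatly and the number stayed within the scatter. The other two steps, a 100-fold lower number from compound 1 to compound 2 (2.01 log units; beyond the scatter) and a 90-fold lower number from compound 1 to compound 3 (1.95 log units; beyond the scatter), are both large, so a change on this chain can matter in this assay. Both start from the ethoxycarbonyl group of compound 1, however, and that group is absent from compound 3 and compound 4.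

No step beyond the scatter is therefore expected, and the range is kept wider on the upper side. The expected step is a 1.4-fold higher number from compound 3 to compound 4 (0.13 log units; within the scatter). For compound 4 the estimated value is 15 ug/mL, with an expected range of 5 ug/mL to 80 ug/mL.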

Compound 4, half-maximal cytotoxic concentration: 177 ug/mL
Beside the measured number, compound 4's estimate is 12-fold (1.07 log units) below it; measured number outside the range, above it.
By their numbers in this assay, from the lowest: compounds 2 and 3 (each within the scatter of the next); then compound 4; then compound 1.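

Hydroxy in place of anilino on a double-bonded nitrogen gives a large change in this assay, a 16-fold higher number from compound 3 to compound 4 (1.20 log units; beyond the scatter), so the end of this chain matters more than the level pair of compound 2 and compound 3 had suggested. The size of the group does not sort the numbers: the groups of compound 2 and compound 4 count the same 4 heavy atoms, yet the step is large, an 18-fold higher number from compound 2 to compound 4 (1.25 log units; beyond the scatter), whereas the much larger group of compound 3 stays level with compound 2. Compound 4 still does not reach the ethoxycarbonyl compound, a 5.6-fold lower number from compound 1 to compound 4 (0.75 log units; beyond the scatter), so the four compounds fall on three levels, with compound 1 highest and compound 2 and compound 3 together lowest.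

Nothing available here accounts for these differences in the number. As far as these compounds go, it remains open whether the high number follows the hydroxy itself, which a methoxy or a simple amine on the double-bonded nitrogen would test, and whether a carboxylic acid in place of ethoxycarbonyl would keep the high number of compound 1.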